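Replacing pyrrolidin-2-yl with pyridin-3-yl in compound 2

The compounds below may be only part of what the source reports. "The series", "measured", "known", "first", "only" and "open" are said of these compounds alone.

In a functional assay on LNCaP cells (Homo sapiens) for antiproliferative activity, read by MTT assay, with a stated time of 24 h (on this read-out higher numbers stand for weaker inhibition and lower numbers for stronger inhibition), compound 2 `COc1ccc(-c2noc(C3CCCN3)n2)cc1OC1CCCC1` gives 43 nM, the lowest number among the measured compounds. The nearest measured number belongs to compound 3 `Fc1ccc(-c2nc(-c3ccccc3)no2)cc1`, at 23700 nM, a gap well beyond the usual scatter. Compound 1 `COc1ccc(-c2noc(-c3ccncc3)n2)cc1OC1CCCC1` gives > 1000000 nM, which is a limit of the assay and not a number.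

Compound 4 `COc1ccc(-c2noc(-c3cccnc3)n2)cc1OC1CCCC1` is still unmeasured. It carries pyridin-3-yl in place of pyrrolidin-2-yl on an aromatic carbon, next to the ring nitrogen and next to the ring oxygen: pyridin-3-yl in place of pyrrolidin-2-yl on an aromatic carbon. Going by the values given here, the one measured step that bears on this change is the swap of pyridin-4-yl for pyrrolidin-2-yl, an at least 23000-fold lower number from compound 1 to compound 2 (4.36 log units; beyond the scatter). That step is large, but it rests on a limit and involves a different pyridinyl group, so it serves only as a guide to the reverse change. In this assay the expected step is large and towards a higher number, a 1400-fold higher number from compound 2 to compound 4 (3.14 log units; beyond the scatter). Compound 4 is estimated at 60000 nM, with an expected range of 2000 nM to 1000000 nM.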

Compound 4, half-maximal inhibitory concentration: > 1000000 nM
Compound 4 ended at the assay's limit (the forecaster's own chance of this, stated with the estimate: 35%); middle value at least 16-fold (1.22 log units) from the limit.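

Placing pyridin-3-yl instead of pyrrolidin-2-yl on this aromatic carbon gives, in this assay, an at least 23000-fold higher number from compound 2 to compound 4 (4.36 log units; beyond the scatter), and the value of compound 4 is a limit of the assay, not a number. Until now, pyridin-4-yl was the only aromatic group compared directly with pyrrolidin-2-yl here, whereas the loss now appears with both pyridinyl groups shown, so it is not confined to pyridin-4-yl. The step between the two pyridinyl compounds cannot be read, and they cannot be ranked against each other: the limit of > 1000000 nM in this assay, at which 2 of the 4 values shown sit.

From the compounds shown here alone, it remains open whether the low number of compound 2 requires the whole pyrrolidin-2-yl ring or only a nitrogen carrying a hydrogen, as in an open-chain amine such as aminomethyl. Going by these compounds, the effect of piperidin-2-yl, a six-membered non-aromatic ring, on this carbon also remains unknown.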